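The compounds below may be only part of what the source reports. "The series", "measured", "known", "first", "only" and "open" are said of these compounds alone.

Of the compounds shown here, three that share one core have been measured in a functional assay on PC-3 cells (Homo sapiens), read by MTT assay, with a stated time of 48 h; on this read-out higher numbers stand for weaker inhibition and lower numbers for stronger inhibition. Compound 1 `CCN(CC)CCNC(=O)c1ccc(C(CC)(CC)c2ccc(OCC(O)C(C)(C)C)c(C)c2)n1CC` gives 220 nM. Compound 3 `CCn1c(C(=O)NCCN)ccc1C(CC)(CC)c1ccc(OCC(O)C(C)(C)C)c(C)c1` gives 940 nM. Compound 2 `CCn1c(C(=O)NCCCN(C)C)ccc1C(CC)(CC)c1ccc(OCC(O)C(C)(C)C)c(C)c1` gives 3100 nM, the highest of the three numbers, so within this small set compound 2 is the weakest inhibitor. The measured steps all change only the amine at the end of the chain on the amide-type nitrogen: a 14-fold higher number from compound 1 to compound 2 (1.15 log units; beyond the scatter), a 4.3-fold higher number from compound 1 to compound 3 (0.63 log units; beyond the scatter) and a 3.3-fold lower number from compound 2 to compound 3 (0.52 log units; beyond the scatter).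

Compound 4 `CCn1c(C(=O)Oc2ccc(CCO)cc2)ccc1C(CC)(CC)c1ccc(OCC(O)C(C)(C)C)c(C)c1` differs from compound 2 in another way: a group of 10 heavy atoms (8 carbon, 2 oxygen; one six-membered aromatic ring of carbon only) in place of a group of 7 heavy atoms (5 carbon, 2 nitrogen; no ring), on a carbonyl carbon. The nitrogen-containing group leaves the carbonyl carbon and a group with two oxygens and one six-membered aromatic ring of carbon only takes its place. Within the data shown here, none of the measured steps covers such a change; they only show that altering the amine end of the chain can move the number by as much as a 14-fold higher number from compound 1 to compound 2 (1.15 log units; beyond the scatter). With nothing closer to lean on, the number for compound 4 is expected to stay near that of compound 2, with wide uncertainty in both directions: a 1.1-fold higher number from compound 2 to compound 4 (0.05 log units; within the scatter). Compound 4 is therefore estimated at 3500 nM, between 900 nM and 14000 nM.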

Compound 4, half-maximal inhibitory concentration: 6300 nM
For compound 4 the middle estimate is 1.8-fold (0.26 log units) below the measured one; low and high end bracket the measured number.
By their numbers in this assay, from the lowest: compound 1; then compound 3; then compound 2; then compound 4.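

In this assay, among these compounds, the earlier steps changed only the amine end of the chain, whereas replacing the whole nitrogen-containing group on the carbonyl carbon gives a 2.0-fold higher number from compound 2 to compound 4 (0.31 log units; beyond the scatter), along with a 6.7-fold higher number from compound 3 to compound 4 (0.83 log units; beyond the scatter) and a 29-fold higher number from compound 1 to compound 4 (1.46 log units; beyond the scatter). Compound 4 thus has the highest number of the four and is the weakest inhibitor in this set, with modest steps from compound 2 and compound 3 but a large one from compound 1. No measurement shown here accounts for this rise.

Compound 4 changes both the atom bonded to the carbonyl carbon and the rest of the group, so the compounds shown cannot separate these two changes. On these data alone, it remains open how the same aromatic ring and hydroxyethyl chain would behave when attached through an amide nitrogen, or how a simple carboxylic acid would compare at this carbonyl carbon.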